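The source may hold more compounds than are shown below. What is called first, only, known or untested is meant among the compounds shown, and "the series" means these compounds.

Compound 1 `CC(C)(C)NCc1c(C(=O)O)nn(-c2ccc(Cl)cc2)c1-c1ccc(F)cc1`: > 623000 nM (a limit)
Compound 2 `CC(C)(C)NCc1c(C(=O)O)nn(-c2ccc(Cl)cc2)c1-c1ccc(Cl)cc1`: 290000 nM
Compound 3 `Cc1ccc(-c2c(CNC(C)(C)C)c(C(=O)O)nn2-c2ccc(Cl)cc2)cc1`: > 629000 nM (a limit)

All three were tested in a functional assay on K562 cells (Homo sapiens) for inhibition, read by sulforhodamine B assay, with a stated time of 48 h; on this read-out higher numbers stand for weaker inhibition of growth and lower numbers for stronger inhibition of growth. Compound 3 stands at > 629000 nM, which is a limit and not a number. Compound 4 `COc1ccc(-c2c(CNC(C)(C)C)c(C(=O)O)nn2-c2ccc(Cl)cc2)cc1` has methoxy in place of methyl on an aromatic carbon, para to a large group: methoxy in place of methyl on an aromatic carbon. The nearest evidence is an at least 2.1-fold higher number from compound 2 to compound 3 (0.33 log units; beyond the scatter), with methyl in place of chloro, and an at least 2.1-fold lower number from compound 1 to compound 2 (0.33 log units; beyond the scatter), with chloro in place of fluoro. Neither step involves methoxy, and only compound 2 has given a number, so no step beyond the scatter is expected in this assay. The expected change is an at least 1.1-fold lower number from compound 3 to compound 4 (0.05 log units; that floor lies within the scatter). For compound 4 the estimate is 550000 nM, with an expected range from 250000 nM to 800000 nM.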

Compound 4, concentration for 50% growth inhibition: > 605000 nM
Compound 4: only a limit was reported; the forecaster's own chance of this, stated with the estimate: 65%; middle value at least 1.1-fold (0.04 log units) away from the limit.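

In this assay compound 4 stands at > 605000 nM, which is a limit and not a number. Methoxy thus joins fluoro and methyl at this place in giving only a limit, and chloro remains the one group here with a measured value: the change from chloro to methoxy gives an at least 2.0-fold higher number from compound 2 to compound 4 (0.31 log units; beyond the scatter). The steps to compound 4 from compound 1 and from compound 3 join two limits and cannot be read.

As far as these compounds go, how far compound 1, compound 3 and compound 4 differ from one another stays open. Also open, from the compounds shown here alone, is what bromo or an amine at this place would give in this assay.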